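The source may hold more compounds than are shown below. What is called first, only, known or untested is meant among the compounds shown, and "the series" means these compounds.

Working notes on the series.

Compound 1 `CCOC(=O)/C=C/c1ccncc1-c1ccc2c(cnn2C)c1` carries an ethyl ester on the shared core. In a functional assay on KB cells (Homo sapiens) for inhibition, read by sulforhodamine B assay, with a stated time of 72 h (a lower number here means a stronger inhibitor of growth, a higher number a weaker inhibitor of growth), compound 1 gives > 10000 nM, which is a limit of the assay and not a number. Compound 2 `Cn1ncc2cc(-c3cnccc3/C=C/C(=O)O)ccc21` is the corresponding acid. In this assay compound 2 gives > 10000 nM, again a limit of the assay. The change between them is hydrogen in place of ethyl on an oxygen next to a carbonyl group and the step it made is a step that the two limits leave unreadable from compound 1 to compound 2; the reading is blocked by the limit of > 10000 nM in this assay, at which 2 of the 3 values shown sit.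

Compound 3 `CCOC(=O)/C=C/c1ccncc1-c1ccc2c(ccn2C)c1` holds a different core; the difference between the two cores is not broken down here. In this assay, for the measured compounds named here, compound 3 gives 6250 nM, the only number in the set so far. Compound 4 `Cn1ccc2cc(-c3cnccc3/C=C/C(=O)O)ccc21` is the acid matching compound 3, the change being (hydrogen in place of ethyl on an oxygen next to a carbonyl group), the same kind of change as that from compound 1 to compound 2, with the place around it read the same in words.

Going by the values given here, no measured step of this kind is readable, so the expectation for compound 4 rests mainly on compound 3 at 6250 nM. Compound 1 and compound 2 each sit at a limit of the assay and give no number to lean on. Compound 4 is expected at 15000 nM, in the range 5000 nM to 50000 nM, meaning an expected step of a 2.4-fold higher number from compound 3 to compound 4 (0.38 log units; beyond the scatter), with a fair chance that only a limit is reported.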

Compound 4, concentration for 50% growth inhibition: > 10000 nM
Compound 4 gave a limit, no number; the forecaster's own chance of this, stated with the estimate: 60%; the middle value lies beyond the limit too.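

In this assay, from the compounds shown here alone, hydrogen in place of ethyl on the core of compound 3 gave an at least 1.6-fold higher number from compound 3 to compound 4 (0.20 log units; that floor lies within the scatter); this is a floor only, so the true size of the step stays unknown and a real loss of growth inhibition is not established. The same change on the core of compound 1 cannot be read, so there are no two sizes to compare, and nothing here shows whether the change carries from one core to the other or behaves differently on each. The reading stops at a single limit of the assay across most of the set: the limit of > 10000 nM in this assay, at which 3 of the 4 values shown sit.

The compounds shown leave open how large the ethyl-to-hydrogen step really is on either core, and whether any of the acids would give a number in this assay. They also leave open how a different group at the same place, such as a primary amide or a methyl ester, would read on these cores.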